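Swapping the Aryl Group on a Sulfonyl Sulfur

The compounds below may be only part of what the source reports. "The series", "measured", "known", "first", "only" and "open" are said of these compounds alone.

Of the compounds shown here, three sharing one core have been measured in a functional assay on MKN-45 cells (Homo sapiens) for cytotoxicity, read by MTT assay, with a stated time of 72 h; on this read-out higher numbers stand for weaker inhibition and lower numbers for stronger inhibition. Compound 1 `COc1cc2c(Oc3ccc(NC(=O)c4cn(-c5ccccc5OC)cn4)cc3F)ccnc2cc1OCCCN1CCN(C)CC1` gives 220 nM. Compound 2 `COc1cc2c(Oc3ccc(NC(=O)/C=C/S(=O)(=O)c4ccccc4F)cc3F)ccnc2cc1OCCCN1CCN(C)CC1` gives 280 nM. Compound 3 `COc1cc2c(Oc3ccc(NC(=O)/C=C/S(=O)(=O)c4ccccc4OC)cc3F)ccnc2cc1OCCCN1CCN(C)CC1` gives 430 nM, the highest of the three numbers, yet its gaps to compound 2 and to compound 1 both lie within the scatter, so the three cannot be told apart on these data.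

Compound 4 `COc1cc2c(Oc3ccc(NC(=O)/C=C/S(=O)(=O)c4ccc(C)cc4)cc3F)ccnc2cc1OCCCN1CCN(C)CC1` differs from compound 3 in one place: 4-methylphenyl in place of 2-methoxyphenyl on a sulfonyl sulfur. Among the compounds with values here, the only measured step that touches the same ring is a 1.5-fold higher number from compound 2 to compound 3 (0.19 log units; within the scatter), a change of substituent on that ring that stayed within the scatter. Within the data shown here, no measured step exchanges the methoxy for a methyl or moves a substituent to another place on this ring, so the bearing of that step is indirect. The expectation is therefore a step of a 1.2-fold lower number from compound 3 to compound 4 (0.09 log units; within the scatter), not beyond the scatter. Compound 4 is estimated at 350 nM, within a range from 150 nM to 900 nM.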

Compound 4, half-maximal inhibitory concentration: 2510 nM
Beside the measured number, compound 4's estimate is 7.2-fold (0.86 log units) below it, outside the stated range (above it).
By their numbers in this assay, from the lowest: compounds 1, 2 and 3 (each within the scatter of the next); then compound 4.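

The aryl group on the sulfonyl sulfur turns out not to be a silent position in this assay: 4-methylphenyl in place of 2-methoxyphenyl gives a 5.8-fold higher number from compound 3 to compound 4 (0.77 log units; beyond the scatter) and 4-methylphenyl in place of 2-fluorophenyl gives a 9.0-fold higher number from compound 2 to compound 4 (0.95 log units; beyond the scatter) as its counterpart. Swapping fluoro for methoxy on this ring had stayed within the scatter, whereas both of these changes go beyond it, so the number does respond to which aryl group sits on the sulfur. No measurement offered here accounts for this rise.

Compound 4 changes both the substituent and its place on the ring, so these compounds cannot separate the effect of the methyl group from that of its place. Going by these compounds, how an amine or a carboxylic acid on this ring would read also stays open.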